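Para-chloro aryl amide variant in the diacylhydrazine series

The source may hold more compounds than are shown below. What is called first, only, known or untested is meant among the compounds shown, and "the series" means these compounds.

Three diacylhydrazines sharing one core have been measured in an assay on cells for agonist activity at ecdysone receptor (Bombyx mori), read by a luciferase reporter, with a stated time of 24 h; a higher number here means that more compound is needed for the effect, a lower number that less compound is needed. Compound 1 `CC(C)(C)N(NC(=O)c1cccc(F)c1)C(=O)c1ccccc1Cl` gives 69.2 nM. Compound 2 `CC(C)(C)N(NC(=O)c1cccc(Br)c1)C(=O)c1ccccc1Cl` gives 191 nM. Compound 3 `Cc1cccc(C(=O)NN(C(=O)c2ccccc2Cl)C(C)(C)C)c1` gives 603 nM and stands highest of the three numbers: its nearest neighbour is compound 2, with a 3.2-fold higher number from compound 2 to compound 3 (0.50 log units; beyond the scatter), and the furthest is compound 1, with an 8.7-fold higher number from compound 1 to compound 3 (0.94 log units; beyond the scatter); between the two halogen analogues the step is a 2.8-fold higher number from compound 1 to compound 2 (0.44 log units; beyond the scatter).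

Compound 4 `CC(C)(C)N(NC(=O)c1ccc(Cl)cc1)C(=O)c1ccccc1Cl` is not yet measured. Relative to compound 3 the change is 4-chlorophenyl in place of 3-methylphenyl on a carbonyl carbon. Going by the values given here, no measured step places a chlorine on the ring or moves a substituent from one ring position to another, so none bears on the change directly. What bears on it indirectly is that, within the measured set, replacing a halogen by methyl raised the number in both cases seen, by an 8.7-fold higher number from compound 1 to compound 3 (0.94 log units; beyond the scatter) and by a 3.2-fold higher number from compound 2 to compound 3 (0.50 log units; beyond the scatter). Returning to a halogen, though at a different position, is therefore expected to give a lower number in this assay for compound 4 than for compound 3, with a step of roughly a 3.0-fold lower number from compound 3 to compound 4 (0.48 log units; beyond the scatter) expected, the different ring position leaving the size uncertain. Compound 4 is estimated at 200 nM, within a range of 50 nM to 800 nM.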

Compound 4, half-maximal effective concentration: 115 nM
Compound 4: middle estimate off by 1.7-fold (0.24 log units), on the high side; the range from low to high includes it.
By their numbers in this assay, from the lowest: compounds 1, 4 and 2 (each within the scatter of the next, the first and the last beyond it); then compound 3.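

In this assay the 4-chlorophenyl group on the carbonyl carbon falls with the two halogen compounds and apart from the methyl compound, with a 5.2-fold lower number from compound 3 to compound 4 (0.72 log units; beyond the scatter) against a 1.7-fold lower number from compound 2 to compound 4 (0.22 log units; within the scatter) and a 1.7-fold higher number from compound 1 to compound 4 (0.22 log units; within the scatter) and so no separation from either halogen analogue. Across these four compounds, all three halogen-bearing aryl groups give lower numbers than 3-methylphenyl and none goes against this, although compound 4 also differs from compound 3 in ring position, so the atom and its place cannot be told apart in this step. No measurement here explains why the chlorine-bearing group reads as it does.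

The compounds shown leave open whether 3-chlorophenyl or 4-methylphenyl would stay with the halogen compounds or with compound 3, and either would separate the substituent from its ring position. They also leave open how a 4-aminophenyl or 4-carboxyphenyl group on the same carbonyl carbon would read, since every substituent so far is a halogen or methyl.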